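Semicarbazone series: removing one chloro from compound 1

The compounds below may be only part of what the source reports. "The series", "measured", "known", "first", "only" and "open" are said of these compounds alone.

Working notes on two measured members of the series and one not yet measured. Compound 1 `O=C(N/N=C/c1ccc(Cl)cc1Cl)Nc1cccc2ccccc12` and compound 2 `O=C(N/N=C/c1ccccc1[N+](=O)[O-])Nc1cccc2ccccc12` share the same core and differ only in the aryl group hanging from the hydrazone. In a functional assay on the whole organism (strain Swiss albino) with Mus musculus as the target, in the maximal electroshock model, with a stated time of 4 h (a lower number here means that less compound is needed, a higher number that more compound is needed for the effect), compound 1 gives 100 mg/kg, the lower of the two numbers shown so far, while compound 2 gives 300 mg/kg, a gap that lies beyond the usual scatter. Among the compounds with values here, no step between compounds with a single structural difference is available, so the change to compound 3 has no measured precedent in this set.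

Compound 3 `O=C(N/N=C/c1ccc(Cl)cc1)Nc1cccc2ccccc12` is compound 1 with one change: hydrogen in place of chloro on an aromatic carbon. Cut one bond further out, the difference reads 2,4-dichlorophenyl to 4-chlorophenyl, so the remaining chloro group is kept.

For this assay, the expected step from compound 1 to compound 3 is a 1.3-fold higher number from compound 1 to compound 3 (0.11 log units; within the scatter), a small rise in the dose needed that may not clear the scatter. Compound 3 is therefore estimated at 130 mg/kg, with a range from 50 mg/kg to 300 mg/kg.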

Compound 3, minimum effective dose: 300 mg/kg
Compound 3: middle estimate off by 2.3-fold (0.36 log units), on the low side, and the stated range covers the measured number.
By their numbers in this assay, from the lowest: compound 1; then compounds 2 and 3 (each within the scatter of the next).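

In this assay the series now has its first step with a single structural difference: a 3.0-fold higher number from compound 1 to compound 3 (0.48 log units; beyond the scatter). This shows that the chloro on the aromatic carbon ortho to a large group and meta to a chloro group matters for the read-out, as its replacement by hydrogen moves the number beyond the scatter even though the other chloro stays in place; the earlier comparison involved a whole change of aryl group and could not isolate any one position. No measurement is at hand that explains the size of this step.

Going by these compounds, it remains open whether the step is specific to chloro or whether another group on this same carbon, such as fluoro, methyl or methoxy, would hold the number near that of the 2,4-dichlorophenyl compound. Also open, on these data alone, is the complementary single change, with hydrogen replacing the other chloro while this one stays, which would show whether that chloro matters to a similar degree.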